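Mirror-image pyrrolidines as agonists at GPR39

The source may hold more compounds than are shown below. What is called first, only, known or untested is meant among the compounds shown, and "the series" means these compounds.

Compound 1 `N#Cc1ccc(N2CCN(Cc3cn4cc(Cl)ccc4n3)CC2)nc1` gives 56 nM in an assay on CHO-K1 cells for agonist activity at G-protein coupled receptor 39 (Homo sapiens), read by FLIPR and calcium flux, with a stated time of 1 h; a higher number here means that more compound is needed for the effect, a lower number that less compound is needed.
Compound 2 `CCc1nc(CN2C[C@H](C(=O)NCc3ccccc3Cl)[C@@H](c3cccnc3)C2)c[nH]1` gives 320 nM in this assay.

Of the two measured compounds, compound 2 has the higher number, so more of it is needed than of compound 1; the gap between them lies beyond the usual scatter. For the measured compounds named here, no pair of measured compounds differs in only one place, so no single structural step has yet been paired with a change in the read-out.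

Compound 3 `CCc1nc(CN2C[C@@H](C(=O)NCc3ccccc3Cl)[C@H](c3cccnc3)C2)c[nH]1` is the mirror image of compound 2: the two compounds have the same atoms and bonds and differ only in configuration as drawn: 2 of 2 stereo elements differ (all stereocentres are inverted: mirror images); a stereocentre at a saturated ring carbon is drawn R in compound 2 and S in compound 3; a stereocentre at a saturated ring carbon is drawn S in compound 2 and R in compound 3. Mirror images commonly differ in how much is needed for an effect, and usually one of the pair needs far more than the other, but nothing measured here says which side compound 2 is on. A change beyond the scatter is expected in this assay, with the direction uncertain. Compound 3 is estimated at 600 nM, within 30 nM to 10000 nM, a step of a 1.9-fold higher number from compound 2 to compound 3 (0.27 log units; within the scatter).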

Compound 3, half-maximal effective concentration in the G-protein coupled receptor 39 assay: 190 nM
Compound 3: the middle estimate sits 3.2-fold (0.50 log units) above what was measured, within the range that was stated.
By their numbers in the G-protein coupled receptor 39 assay, from the lowest: compound 1; then compounds 3 and 2 (each within the scatter of the next).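

For the compounds shown here, in the G-protein coupled receptor 39 assay, this is the first comparison that can be read: compound 2 gives 320 nM, compound 3 gives 190 nM, and the pair shows a 1.7-fold lower number from compound 2 to compound 3 (0.23 log units; within the scatter), so inverting both ring stereocentres leaves the two mirror images indistinguishable on this read-out. In a physicochemical assay for permeability (on this read-out lower numbers stand for lower permeability and higher numbers for higher permeability), compound 2 gives 1.2 10^-6 cm/s, compound 3 gives 0.8 10^-6 cm/s, and the same pair shows a 1.5-fold lower number from compound 2 to compound 3 (0.18 log units; within the scatter), so the two cannot be told apart on that read-out either. The comparison is a clean one, since only one thing separates the pair: the fact that compounds 2 and 3 differ only in the configuration as drawn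

The compounds shown leave open whether a change to the atoms themselves would matter more than this change of configuration, for example a methoxy group or a carboxylic acid in place of the chlorine. They also leave open how either mirror image relates to compound 1, which differs from them in more than one place.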